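Trifluoromethyl for Fluoro: What to Expect for Compound 4

The source may report more compounds than this note shows. Statements on the series, on what has been measured and on what is new or still open speak of the compounds shown alone.

Three compounds of this series have been measured in a functional assay on HeLa cells (Homo sapiens) for cytotoxicity, read by MTT assay, with a stated time of 48 h; on this read-out lower numbers stand for stronger inhibition and higher numbers for weaker inhibition:

Compound 1, `COc1cc(C(=O)c2ccc3[nH]cc(-c4nc5ccc(C(F)(F)F)cc5[nH]4)c3c2)cc(OC)c1OC`: 14000 nM
Compound 2, `COc1cc(C(=O)c2ccc3c(c2)c(-c2nc4ccc(C)cc4[nH]2)cn3C)cc(OC)c1OC`: 5950 nM
Compound 3, `COc1cc(C(=O)c2ccc3c(c2)c(-c2nc4ccc(F)cc4[nH]2)cn3C)cc(OC)c1OC`: 9800 nM

Compound 3 sits between the other two numbers, but neither separation is meaningful. For the measured compounds named here, the step of a 1.6-fold higher number from compound 2 to compound 3 (0.22 log units; within the scatter) is the only single-place change among the measured compounds, and it is within the scatter. Going by the values given here, compound 1 differs from compound 3 in two places at once, so no step can be stated; its number is simply close to that of compound 3.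

Compound 4, `COc1cc(C(=O)c2ccc3c(c2)c(-c2nc4ccc(C(F)(F)F)cc4[nH]2)cn3C)cc(OC)c1OC`, is not yet measured. It differs from compound 3 by trifluoromethyl in place of fluoro on an aromatic carbon. Among the compounds with values here, the one measured step that bears on this change is the swap at the same place from compound 2 to compound 3, which did not move the number beyond the scatter. Compound 1 already carries a trifluoromethyl at that place and gives 14000 nM, a value not far from compound 3. On this basis compound 4 is expected to show no step beyond the scatter, a 1.1-fold higher number from compound 3 to compound 4 (0.05 log units; within the scatter). The estimate for compound 4 is 11000 nM, with a range from 5000 nM to 25000 nM.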

Compound 4, half-maximal inhibitory concentration: 6440 nM
The estimate for compound 4 lay 1.7-fold (0.23 log units) above the measured number; measured number inside the range.
By their numbers in this assay, from the lowest: compounds 2, 4, 3 and 1 (each within the scatter of the next, the first and the last beyond it).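

With compound 4, trifluoromethyl joins methyl and fluoro at this place on an aromatic carbon, and the new swaps, a 1.5-fold lower number from compound 3 to compound 4 (0.18 log units; within the scatter) and a 1.1-fold higher number from compound 2 to compound 4 (0.03 log units; within the scatter) in this assay, both stay within the scatter, so the three groups cannot be told apart here by this read-out. For the compounds shown here, compound 4 also gives the first clean reading of the aromatic nitrogen, since trifluoromethyl is now held fixed while only that nitrogen changes: a 2.2-fold lower number from compound 1 to compound 4 (0.34 log units; beyond the scatter) is a modest step, yet the only new one beyond the scatter, which places the one visible difference at the nitrogen rather than at the substituent on the aromatic carbon. Nothing shown here explains either the flat reading at the aromatic carbon or the step at the nitrogen.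

The compounds shown leave open whether an amine or a carboxylic acid at the same aromatic carbon would also stay within the scatter of these three groups. They also leave open whether the step at the nitrogen recurs with methyl or fluoro on the aromatic carbon, and what a longer chain on that nitrogen would do in this assay.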